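Adding a Methyl to the Unsaturated Arm of Compound 2

The source may hold more compounds than are shown below. What is called first, only, known or untested is meant among the compounds shown, and "the series" means these compounds.

Compound 1 `COc1cc(NC(C)CCCNC(=O)Nc2ccc(Cl)c(C(F)(F)F)c2)c2ncccc2c1` has no result in an ADME assay on L6 cells (Rattus norvegicus) for cytotoxicity, read by resazurin assay, with a stated time of 70 h; on this read-out higher numbers stand for weaker inhibition and lower numbers for stronger inhibition: for compound 1 the entry reads "not determined" (no result reported). Among the compounds with values here, compound 2 `COc1cc(NC(C)CCCNC(=O)NNC(=O)/C=C/c2ccccc2)c2ncccc2c1` therefore stands alone as the only number available: in this assay compound 2 gives 13900 nM. Compound 3 `COc1cc(NC(C)CCCNC(=O)NNC(=O)/C(C)=C/c2ccccc2)c2ncccc2c1` differs from compound 2 in one place: 1-methyl-2-phenylethenyl in place of 2-phenylethenyl on a carbonyl carbon. Within the data shown here, no step between measured compounds of this kind has been recorded, so there is no precedent here for this change. The expectation is that the step of a 1.2-fold lower number from compound 2 to compound 3 (0.06 log units; within the scatter) stays within the usual scatter, with no clear direction. Compound 3 is thus estimated at 12000 nM, most likely between 4000 nM and 40000 nM.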

Compound 3, half-maximal inhibitory concentration: 36500 nM
For compound 3 the middle estimate is 3.0-fold (0.48 log units) below the measured one; the range from low to high includes it.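

In this assay, 1-methyl-2-phenylethenyl in place of 2-phenylethenyl on a carbonyl carbon gives a 2.6-fold higher number from compound 2 to compound 3 (0.42 log units; beyond the scatter). This first measured step shows that this part of the molecule responds to a small change: one extra carbon modestly weakens inhibition of the cells. No measurement here explains why the number rises. As far as these compounds go, whether an ethyl group or an amine in place of that methyl would raise the number further, leave it unchanged or lower it remains open.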